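A few compounds are considered here, and "the series" means these few. Any claim that something is new, unique, unknown or untested is made for them only; others in the source may bear on it.

Measured compounds:
- compound 1 `N/C(CC(O)c1ccc2ccccc2c1)=N\N=C\c1cccnc1`: no result in an ADME assay on L6 cells (Rattus norvegicus) for cytotoxicity, read by resazurin assay, with a stated time of 72 h; a lower number here means a stronger inhibitor, a higher number a weaker inhibitor
- compound 2 `N/C(CC(O)c1cccc2ccccc12)=N\N=C\c1ccc(C(F)(F)F)cc1`: 26000 nM

Compound 1 stands without a number in this assay, where compound 1 is recorded as "not determined" (no result reported). Among the measured compounds shown here, the only value in the set comes from compound 2, which in this assay gives 26000 nM, a weak cytotoxic effect. Compound 3 `N/C(CC(O)c1ccc2ccccc2c1)=N\N=C\c1ccc(Cl)c(Cl)c1` is the next compound to be measured. Relative to compound 1 it carries the change (3,4-dichlorophenyl in place of pyridin-3-yl on a carbon with a double bond to nitrogen), that is, 3,4-dichlorophenyl in place of pyridin-3-yl on a carbon with a double bond to nitrogen.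

For the measured compounds named here, no step between two measured compounds is available, so no size of step for this exchange can be read from the series. For the step from compound 1 to compound 3 in this assay the expectation is a shift of modest size at most, within or only slightly beyond the usual scatter, in the direction of somewhat stronger cytotoxicity. The anchor for the estimate is compound 2, which gives 26000 nM in this assay. Compound 3 is therefore expected to give about 20000 nM in this assay, with a plausible range from 6000 nM to 70000 nM.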

Compound 3, half-maximal inhibitory concentration: 100000 nM
The estimate for compound 3 lay 5.0-fold (0.70 log units) below the measured number; the measured number lies above the stated range.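

No new step can be read from compound 1 to compound 3: in this assay compound 1 is recorded as "not determined" (no result reported) and compound 3 gives 100000 nM with no number to set it against. The compounds shown leave open what exchanging pyridin-3-yl for 3,4-dichlorophenyl alone does in this assay on the shared core. Nothing available bears on the result.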